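This account rests on a few compounds, and the source may have more. Where it says the series, first, only, none or still open, it means among the compounds named here.

Compound 1, `CCNC(=O)c1nc(-c2cc(OC)c(OC)c(OC)c2)n(-c2ccc(OC)cc2)n1`, gives 60% in a functional assay on the whole organism for inhibition, with Rattus norvegicus as the target, read by paw edema, with stated times of 30 min and 1 h, at a dose of 0.28 mmol/kg by the oral route; on this read-out higher numbers stand for more inhibition at the one dose given (going by the name of the read-out) and lower numbers for less inhibition. Compound 2, `COc1ccc(-n2nc(C(=O)Nc3ccccc3OC)nc2-c2cc(OC)c(OC)c(OC)c2)cc1`, gives 52% in this assay.

Of the two measured compounds, compound 1 has the higher number, but the step of a number 8 percentage points lower from compound 1 to compound 2 (within the scatter) is within the scatter, so the two cannot be told apart in this assay. Compound 3, `COc1ccc(-n2nc(C(=O)Nc3ccc(C)cc3)nc2-c2cc(OC)c(OC)c(OC)c2)cc1`, has not yet been measured. Compared with compound 1 it differs as follows: 4-methylphenyl in place of ethyl on an amide-type nitrogen. For the measured compounds named here, the one measured step that bears on this change is a number 8 percentage points lower from compound 1 to compound 2 (within the scatter), where a different aryl group took the place of the same ethyl group on the same amide-type nitrogen; it made no difference beyond the scatter. On that basis the step of a number 5 percentage points lower from compound 1 to compound 3 (within the scatter) is expected to be small, within the scatter, with no clear direction. Compound 3 is therefore estimated at 55% in this assay, likely between 40% and 70%.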

Compound 3, a percentage reported as inhibition, in the whole organism at one dose (the size of the read-out at that dose, not a potency): 38%
The estimate for compound 3 lay 17 percentage points above the measured number; measured number outside the range, below it.
By their numbers in this assay, from the lowest: compound 3; then compounds 2 and 1 (each within the scatter of the next).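

At the amide-type nitrogen, the choice of group now clearly matters: in this assay the change from ethyl to 4-methylphenyl gives a number 22 percentage points lower from compound 1 to compound 3 (beyond the scatter), a loss of inhibition that the 2-methoxyphenyl group had not shown beyond the scatter. The two aryl groups also differ from each other, with a number 14 percentage points lower from compound 2 to compound 3 (beyond the scatter), so placing a six-membered aromatic ring on this nitrogen does not by itself set the outcome; which ring it is counts too. No measurement at hand accounts for these differences.

As far as these compounds go, the 2-methoxyphenyl and 4-methylphenyl groups differ both in their substituent and in where it sits, so the contribution of each remains open. Plain phenyl or 4-methoxyphenyl could separate the two, while a longer alkyl chain such as butyl would show whether ethyl can be extended.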